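The source may hold more compounds than are shown below. What is called first, only, known or untested is meant among the compounds shown, and "the series" means these compounds.

Compound 1 `COc1cc(F)c(CCCNc2cc(Cl)ccc2-n2cncn2)cc1OC` carries a chloro group on the shared core together with a fluoro group on an aromatic carbon of a six-membered aromatic ring of carbon only. In a functional assay on cells for negative allosteric modulation of metabotropic glutamate receptor 7 (Rattus norvegicus), read by fluorescence and calcium flux, with stated times of 142 s and 120 s (on this read-out higher numbers stand for weaker inhibition and lower numbers for stronger inhibition), compound 1 gives > 10000 nM, which is a limit of the measurement and not a number. Compound 1 therefore stands only at the weak edge of what was seen, as the limit of > 10000 nM in this assay, at which 1 of the 3 values shown sits, shows. Two related compounds carry a trifluoromethoxy group in place of the chloro group. Compound 2 `COc1ccc(CCCNc2cc(OC(F)(F)F)ccc2-n2cncn2)cc1OC` lacks the fluoro group and gives 1600 nM; 1620 nM (2 entries) in this assay. Compound 3 `COc1cc(F)c(CCCNc2cc(OC(F)(F)F)ccc2-n2cncn2)cc1OC` keeps the fluoro group and gives 1300 nM; 1320 nM (2 entries) in this assay. The repeated entries of compound 2 the several entries of compound 2 in this assay, 1600 nM; 1620 nM (2 entries) and of compound 3 the several entries of compound 3 in this assay, 1300 nM; 1320 nM (2 entries) agree closely, and the two compounds sit within the usual scatter of each other. Compound 4 `COc1ccc(CCCNc2cc(Cl)ccc2-n2cncn2)cc1OC` is compound 1 with hydrogen in place of fluoro on an aromatic carbon. Among the compounds with values here, no measured step covers this change directly. In this assay the change is expected to amount to a step that the limit leaves unreadable from compound 1 to compound 4, with no shift beyond the scatter in either direction. Compound 4 is therefore expected to give about 15000 nM, between 5000 nM and 50000 nM, most likely again reported only as a limit.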

Compound 4, half-maximal inhibitory concentration: > 10000 nM
Compound 4 was reported as a limit; the forecaster's own chance of this, stated with the estimate: 70%; the middle value lies beyond the limit too.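

Compound 1 and compound 4 are both reported only as limits of the measurement, not as numbers, so no step can be read for hydrogen in place of fluoro. The compounds shown leave open whether this change alters inhibition when the chloro group is present.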